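The compounds below may be only part of what the source reports. "The series", "measured", "known", "first", "only" and "open" are said of these compounds alone.

Working notes on the series. Two thiosemicarbazone analogues have been characterised in a functional assay on HeLa cells (Homo sapiens) for inhibition, read by MTT assay (a higher number here means a weaker inhibitor, a lower number a stronger inhibitor), so far. Compound 1 `COc1ccc(/C=N/NC(=S)N/N=C2\C(=O)Nc3ccc(C)cc32)cc1O` gives 2730 nM in this assay, and compound 2 `O=C1Nc2ccc(Br)cc2/C1=N/NC(=S)N/N=C/c1ccc(Br)cc1` gives 4680 nM in this assay. Compound 1 has the lowest of the two numbers, but the gap to compound 2 falls within the scatter of repeated measurements, so the two values show no separation that can be read as a real difference.

Compound 3 `Cc1ccc2c(c1)/C(=N/NC(=S)N/N=C/c1c(F)cccc1Cl)C(=O)N2` has not yet been measured in this assay. It differs from compound 1 in one place: 2-chloro-6-fluorophenyl in place of 3-hydroxy-4-methoxyphenyl on a carbon with a double bond to nitrogen. The change removes the one hydrogen-bond donor and two hydrogen-bond acceptors that the leaving group carried and brings in a halogenated ring with none.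

Among the measured compounds shown here, no pair of measured compounds differing in one place is available to size this kind of change. What the two measured values do show is that a different aryl group on that carbon, as in compound 2, left the number within the scatter of compound 1. On that basis the step from compound 1 to compound 3 is expected to be small, a 1.3-fold higher number from compound 1 to compound 3 (0.11 log units; within the scatter), with no clear direction beyond the scatter. Compound 3 is therefore estimated at 3500 nM in this assay, within a range from 1200 nM to 10000 nM.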

Compound 3, half-maximal inhibitory concentration: 1510 nM
Estimate against measurement, compound 3: 2.3-fold (0.37 log units) above, and the stated range covers the measured number.
By their numbers in this assay, from the lowest: compounds 3, 1 and 2 (each within the scatter of the next, the first and the last beyond it).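

Among the compounds shown here, the step measured in this assay is a 1.8-fold lower number from compound 1 to compound 3 (0.26 log units; within the scatter) and it is the first single-place step at this position, on a carbon with a double bond to nitrogen. It shows that 3-hydroxy-4-methoxyphenyl, with its hydrogen-bond donor and acceptors, can give way to 2-chloro-6-fluorophenyl, which has neither, while the number stays within the scatter, so in this one pair the number does not depend on keeping those donor and acceptor atoms on the ring. Nothing at hand bears on why the number holds across this change, and the step gives its size only.

The compounds shown leave open whether the chlorine and the fluorine each contribute on their own, since both enter together in a single step, and likewise whether the hydroxy and the methoxy can be lost separately. They also leave open how far this position tolerates a different kind of group, such as a carboxylic acid or an amine on the ring, or a saturated cyclohexyl ring in place of the aromatic one.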